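Ethyl for methyl on the piperazine of compound 2

A few compounds are considered here, and "the series" means these few. Any claim that something is new, unique, unknown or untested is made for them only; others in the source may bear on it.

Measured so far:
compound 1 `CCN1CCN(c2ccc(-c3nn(Cc4cn(Cc5ccccc5)nn4)c4nc(NC)ncc34)cn2)CC1` — 6200 nM
compound 2 `CNc1ncc2c(-c3ccc(N4CCN(C)CC4)nc3)nn(CC3CCCC3)c2n1` — 60 nM

In an assay for inhibition of proto-oncogene tyrosine-protein kinase receptor Ret (Homo sapiens), read by 33P incorporation, in the presence of a further agent that is not named here (a lower number here means a stronger inhibitor, a higher number a weaker inhibitor), compound 2 gives 60 nM, the lower of the two numbers; compound 1 sits at 6200 nM, a gap well beyond the scatter. Compound 3 `CCN1CCN(c2ccc(-c3nn(CC4CCCC4)c4nc(NC)ncc34)cn2)CC1` differs from compound 2 by methyl in place of hydrogen on a saturated chain carbon bound to an amine nitrogen in a ring. Within the data shown here, no measured pair isolates this change, so the step size is not known; a change this small is expected to stay within the scatter, in either direction. The step of a 1.2-fold higher number from compound 2 to compound 3 (0.07 log units; within the scatter) is the expectation here. Compound 3 is estimated at 70 nM, with a range from 25 nM to 200 nM.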

Compound 3, half-maximal inhibitory concentration: 440 nM
Compound 3: middle estimate off by 6.3-fold (0.80 log units), on the low side; the whole stated range lies below it.
By their numbers in this assay, from the lowest: compound 2; then compound 3; then compound 1.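

Going from 4-methylpiperazin-1-yl to 4-ethylpiperazin-1-yl is not a neutral swap in this assay: the step is a 7.3-fold higher number from compound 2 to compound 3 (0.87 log units; beyond the scatter) and shows that this single added methyl counts. With the 4-ethylpiperazin-1-yl held fixed, cyclopentyl in place of 1-benzyl-1H-1,2,3-triazol-4-yl gives a 14-fold lower number from compound 1 to compound 3 (1.15 log units; beyond the scatter) and remains the larger of the two steps. Nothing available here explains either step.

Open, on these data alone, is how an unsubstituted piperazine or a longer chain such as propyl would read in this assay on this ring. Also open, as far as these compounds go, is whether cyclohexyl or cyclopropyl would match cyclopentyl.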